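Tetrahydroquinoline carboxamides: acyl variation on the ring nitrogen

A few compounds are considered here, and "the series" means these few. Any claim that something is new, unique, unknown or untested is made for them only; others in the source may bear on it.

Measured so far:
compound 1, `CC(=O)N1c2ccccc2CCC1C(=O)Nc1ccccc1O`, 89600 nM
compound 2, `O=C(Nc1ccccc1C(F)(F)F)C1CCc2ccccc2N1`, 45500 nM
compound 3, `COc1ccc(NC(=O)C2CCc3ccccc3N2)cc1`, 51400 nM

All three values come from a functional assay on MDA-MB-231 cells (Homo sapiens) for cytotoxicity, read by sulforhodamine B assay, with a stated time of 72 h; on this read-out lower numbers stand for stronger inhibition of growth and higher numbers for weaker inhibition of growth. Compound 1 gives the highest number of the three, but its nearest neighbour is compound 3 and the gap to compound 2 is likewise within the scatter, so the three compounds cannot be placed in any order on this read-out. Going by the values given here, no pair among them differs in a single place, so no step between measured compounds is available.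

Compound 4, `O=C(Nc1ccccc1O)C1CCc2ccccc2N1C(=O)c1ccccc1`, is not yet measured. It differs from compound 1 by phenyl in place of methyl on a carbonyl carbon, which at one bond further out reads acetyl to benzoyl. Compounds 2 and 3 carry no acyl group on the ring nitrogen at all, so the effect of acyl size at this position is not shown by any measured pair.

Among the compounds with values here, with no directly comparable step in hand, the step from compound 1 to compound 4 is expected to be small, a 1.4-fold lower number from compound 1 to compound 4 (0.14 log units; within the scatter), with no clear direction beyond the scatter. Compound 4 is accordingly estimated at 65000 nM in this assay, within a range from 20000 nM to 200000 nM.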

Compound 4, concentration for 50% growth inhibition: 4210 nM
The estimate for compound 4 lay 15-fold (1.19 log units) above the measured number, outside the stated range (below it).
By their numbers in this assay, from the lowest: compound 4; then compounds 2, 3 and 1 (each within the scatter of the next).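

In this assay, going by these compounds alone, the acyl group on the ring nitrogen is the first place where a single change is seen to move the number beyond the scatter, with phenyl in place of methyl on a carbonyl carbon giving a 21-fold lower number from compound 1 to compound 4 (1.33 log units; beyond the scatter) for the change from acetyl to benzoyl. Within the data shown here, the position is therefore not indifferent to what the carbonyl carbon carries, which the earlier compounds, with no pair among them differing in one place, could not show. No measurement at hand offers an explanation for this step, which so far rests on one pair.

Still open, on these data alone, is whether the step needs an aromatic ring on the carbonyl carbon or whether other groups there, such as cyclohexyl, a longer chain such as propyl, or a phenyl ring carrying a methoxy group or a dimethylamino group, would give a similar number. Also open, as far as these compounds go, is whether benzoyl on the ring nitrogen of compound 2 or compound 3 would give a step of like size.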